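The compounds below may be only part of what the source reports. "The series", "measured", "known", "first", "only" and "open" are said of these compounds alone.

Measured compounds in a functional assay on DU-145 cells (Homo sapiens) for inhibition, read by sulforhodamine B assay, with a stated time of 48 h; on this read-out lower numbers stand for stronger inhibition of growth and higher numbers for weaker inhibition of growth:

compound 1 `O=C(Nc1cccc(-n2cc(-c3ccncc3)c(-c3ccc(Cl)c(O)c3)n2)c1)Nc1cccc(C(F)(F)F)c1` — > 32500 nM, a limit of the assay
compound 2 `COc1cc(-c2nn(-c3cccc(NC(=O)Nc4cc(C(F)(F)F)cc(C(F)(F)F)c4)c3)cc2-c2ccncc2)ccc1Cl` — 5040 nM
compound 3 `COc1cc(-c2nn(-c3cccc(NC(=O)Nc4cccc(C(F)(F)F)c4)c3)cc2-c2ccncc2)ccc1Cl` — > 50000 nM, a limit of the assay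

Compound 3 stands at a limit of this assay, > 50000 nM, so no number is known for it. Among the three values shown, compound 2 alone gives a number, 5040 nM. Compound 1 likewise sits at a limit, > 32500 nM.

Compound 4 `COc1cc(-c2nn(-c3cccc(NC(=O)c4ccccc4)c3)cc2-c2ccncc2)ccc1Cl` differs from compound 3 in one place: phenyl in place of (3-(trifluoromethyl)phenyl)amino on a carbonyl carbon. Of the measured steps, an at least 9.9-fold higher number from compound 2 to compound 3 (0.99 log units; beyond the scatter) is the one that bears on this change, since it too removes a trifluoromethyl from the ring that hangs off the urea; that removal pushed the number up past the limit. The other step, a step that the two limits leave unreadable from compound 1 to compound 3, sits between two limits the limit of > 32500 nM in this assay, at which 1 of the 3 values shown sits, and the limit of > 50000 nM in this assay, at which 1 of the 3 values shown sits, and gives no usable size. Compound 4 goes further in the same direction, dropping the remaining trifluoromethyl together with the amino, and nothing shown suggests that a bare phenyl on that carbonyl carbon recovers what compound 3 has lost. The step from compound 3 to compound 4 in this assay is therefore expected to be flat or upward, a step that the limit leaves unreadable from compound 3 to compound 4, with a limit the most likely outcome. Compound 4 is estimated at 60000 nM, range 20000 nM to 150000 nM.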

Compound 4, concentration for total growth inhibition: 54700 nM
Estimate against measurement, compound 4: 1.1-fold (0.04 log units) above; the measured number falls inside the stated range.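

No step can be read from compound 3 to compound 4 in this assay, because compound 3 stands at a limit of the assay: the limit of > 50000 nM in this assay, at which 1 of the 4 values shown sits.

The compounds shown leave open whether phenyl in place of (3-(trifluoromethyl)phenyl)amino on the carbonyl carbon changes growth inhibition at all.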